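A few compounds are considered here, and "the series" means these few. Any claim that something is new, unique, unknown or untested is made for them only; others in the source may bear on it.

Three compounds share one core and differ only in the group attached to a carbonyl carbon. In an assay on HL-60 cells for agonist activity at vitamin D3 receptor (Homo sapiens), read by microscopy, with a stated time of 96 h (on this read-out higher numbers stand for an effect only at larger amounts of compound and lower numbers for an effect already at smaller amounts), compound 1 `CCn1c(C(=O)NCCN)ccc1C(CC)(CC)c1ccc(OCC(O)C(C)(C)C)c(C)c1` gives 10 nM, compound 2 `CC[C@@H](C)[C@H](NC(=O)c1ccc(C(CC)(CC)c2ccc(OCC(O)C(C)(C)C)c(C)c2)n1CC)C(=O)O` gives 2.3 nM, and compound 3 `CCn1c(C(=O)N(C)CC(=O)O)ccc1C(CC)(CC)c1ccc(OCC(O)C(C)(C)C)c(C)c1` gives 740 nM, the highest number of the three: a 74-fold higher number from compound 1 to compound 3 (1.87 log units; beyond the scatter) and a 320-fold higher number from compound 2 to compound 3 (2.51 log units; beyond the scatter). Compound 4 `CCn1c(C(=O)Oc2ccc(CCO)cc2)ccc1C(CC)(CC)c1ccc(OCC(O)C(C)(C)C)c(C)c1` brings (a group of 10 heavy atoms (8 carbon, 2 oxygen; one six-membered aromatic ring of carbon only) in place of a group of 6 heavy atoms (3 carbon, 1 nitrogen, 2 oxygen; no ring), on a carbonyl carbon). Within the data shown here, no measured step covers this particular exchange; the two steps ending at compound 3 only show that what sits on this carbonyl carbon can move the result by large amounts, so a step that is not small is expected here as well, in this assay most likely downward from the weak number of compound 3. For compound 4 the estimate is 100 nM, between 10 nM and 1000 nM, an expected 7.4-fold lower number from compound 3 to compound 4 (0.87 log units; beyond the scatter).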

Compound 4, half-maximal effective concentration: 5100 nM
Beside the measured number, compound 4's estimate is 51-fold (1.71 log units) below it; measured number above the stated range.
By their numbers in this assay, from the lowest: compound 2; then compound 1; then compound 3; then compound 4.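

In this assay, the group with the six-membered aromatic ring pushes the number higher still (a 6.9-fold higher number from compound 3 to compound 4 (0.84 log units; beyond the scatter)), so compound 3 did not mark the upper end for this carbonyl carbon. The gaps to the two best compounds are wider (a 2200-fold higher number from compound 2 to compound 4 (3.35 log units; beyond the scatter); a 510-fold higher number from compound 1 to compound 4 (2.71 log units; beyond the scatter)), and the range of results at this one place grows with them. No measurement shown gives a reason for this rise.

Which part of the new group matters stays open: the ring, its hydroxyethyl chain or the oxygen on the carbonyl carbon. The same ring joined through an amide nitrogen would help separate these.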